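Replacing the aryl group of compound 3

A few compounds are considered here, and "the series" means these few. Any claim that something is new, unique, unknown or untested is made for them only; others in the source may bear on it.

Values measured so far in a functional assay on MCF7 cells (Homo sapiens) for inhibition, read by CCK-8 assay, with a stated time of 48 h; on this read-out lower numbers stand for stronger inhibition and higher numbers for weaker inhibition
- compound 1 `COc1cc(-c2ccnc3cc(-c4ccc(F)cc4)nn23)cc(OC)c1OC` gives 1280 nM
- compound 2 `COc1cc(-c2ccnc3cc(-c4ccccc4)nn23)cc(OC)c1OC` gives 254 nM
- compound 3 `COc1cc(-c2ccnc3cc(-c4ccc(N(C)C)cc4)nn23)cc(OC)c1OC` gives 44 nM

Compound 3 holds the lowest number of the three. The series shows a 5.8-fold lower number from compound 2 to compound 3 (0.76 log units; beyond the scatter) as a modest step and a 29-fold lower number from compound 1 to compound 3 (1.46 log units; beyond the scatter) as a large one, while a 5.0-fold lower number from compound 1 to compound 2 (0.70 log units; beyond the scatter) is also modest.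

The next structure is compound 4 `COc1ccc(-c2cc3nccc(-c4cc(OC)c(OC)c(OC)c4)n3n2)cc1N` with 3-amino-4-methoxyphenyl in place of 4-(dimethylamino)phenyl on an aromatic carbon and the rest of the core unchanged.

Among the measured compounds shown here, all three measured steps change the same aryl group, so they are the only guide here. None of them tests a methoxy group or an unsubstituted amino group, which leaves the direction uncertain. Compound 4 keeps a nitrogen on the aryl group as compound 3 does, and the modest step of a 5.8-fold lower number from compound 2 to compound 3 (0.76 log units; beyond the scatter) is the reason for leaning towards a lower number. In this assay the expected change is a 1.8-fold lower number from compound 3 to compound 4 (0.25 log units; within the scatter) and it may not clear the scatter. For compound 4 the estimated value is 25 nM with an expected range from 4 nM to 150 nM on this small evidence.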

Compound 4, half-maximal inhibitory concentration: 27 nM
Compound 4: the middle estimate sits 1.1-fold (0.03 log units) below what was measured, within the range that was stated.
By their numbers in this assay, from the lowest: compounds 4 and 3 (each within the scatter of the next); then compound 2; then compound 1.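

In this assay, 3-amino-4-methoxyphenyl in place of 4-(dimethylamino)phenyl gives a 1.6-fold lower number from compound 3 to compound 4 (0.21 log units; within the scatter) and so leaves the two groups level, which shows that a low number at this position does not depend on the 4-(dimethylamino)phenyl group. The entering group has a different substitution pattern and carries 1 hydrogen-bond donor where the leaving group has 0, yet the two read alike on this aromatic carbon of the five-membered ring. The new group also holds clear margins over the simpler aryl groups, with a 9.4-fold lower number from compound 2 to compound 4 (0.97 log units; beyond the scatter) against phenyl and a 47-fold lower number from compound 1 to compound 4 (1.68 log units; beyond the scatter) against 4-fluorophenyl, so two different nitrogen-bearing aryl groups now stand apart from those two. Nothing on hand accounts for why these two aryl groups read alike.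

The compounds shown leave open whether the amino group or the methoxy group carries the result, which 3-aminophenyl and 4-methoxyphenyl at this position would separate. Also open, going by these compounds, is how a morpholine ring, a carboxylic acid or an amide on this aryl group would read with the rest of the shared core unchanged.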